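Ring to Oxime Ether on the Shared Core

The compounds below may be only part of what the source reports. "The series", "measured", "known", "first", "only" and "open" are said of these compounds alone.

Measured so far in a functional assay for activation of Alpha-1A adrenergic receptor (Homo sapiens), read by calcium flux; a higher number here means that more compound is needed for the effect, a lower number that less compound is needed: compound 1, `Cc1ncc(-c2ccccc2NCC2=NCCN2)o1`, gives 110 nM; compound 2, `c1csc(-c2ccccc2NCC2=NCCN2)c1`, gives 2.24 nM; compound 3, `c1ccc(-c2cnoc2)c(NCC2=NCCN2)c1`, gives 45.7 nM.

Compound 3 holds the second highest of the three numbers: it sits closest to compound 1, with a 2.4-fold lower number from compound 1 to compound 3 (0.38 log units; beyond the scatter), and farthest from compound 2, with a 20-fold higher number from compound 2 to compound 3 (1.31 log units; beyond the scatter). Compound 4, `CO/N=C(\C)c1ccccc1NCC1=NCCN1`, carries a group of 5 heavy atoms (3 carbon, 1 nitrogen, 1 oxygen; no ring) in place of a group of 5 heavy atoms (3 carbon, 1 nitrogen, 1 oxygen; one five-membered aromatic ring with 2 hetero atoms), on an aromatic carbon. Within the data shown here, no measured step removes a ring at this site, but both steps that swap the group on that aromatic carbon were sizeable, one modest and one large. A step of uncertain direction is therefore expected, estimated as a 1.8-fold higher number from compound 3 to compound 4 (0.24 log units; within the scatter). Compound 4 is expected at 80 nM, within 15 nM to 400 nM.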

Compound 4, half-maximal effective concentration: 20.9 nM
For compound 4 the middle estimate is 3.8-fold (0.58 log units) above the measured one, and the stated range covers the measured number.
By their numbers in this assay, from the lowest: compound 2; then compound 4; then compound 3; then compound 1.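

In this assay, the oxime ether shows that a ring is not required on this aromatic carbon, since this group with no ring gives a lower number than either oxazole-type ring (a 2.2-fold lower number from compound 3 to compound 4 (0.34 log units; beyond the scatter); a 5.3-fold lower number from compound 1 to compound 4 (0.72 log units; beyond the scatter)). It does not match thiophen-2-yl, however (a 9.3-fold higher number from compound 2 to compound 4 (0.97 log units; beyond the scatter)). Nothing available here explains these differences.

The compounds shown leave open whether a longer chain on the oxime oxygen, such as ethyl in place of methyl, would lower the number further. From the compounds shown here alone, how an amine or a carboxylic acid on this aromatic carbon would compare also remains open.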